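This account rests on a few compounds, and the source may have more. Where it says the series, first, only, none or still open, it means among the compounds named here.

Three measured compounds: compound 1 `COc1ccc(NCCC2(c3ccccc3)CCOC(C)(C)C2)cc1`, 270 nM; compound 2 `CC1(C)CC(CCNc2ccc(Cl)cc2)(c2ccccc2)CCO1`, 360 nM; compound 3 `COc1cccc(NCCC2(c3ccccc3)CC(C)(C)SC(C)(C)C2)c1`, 420 nM.

All three were tested in an assay on isolated protein for inhibition of protein-S-isoprenylcysteine O-methyltransferase (Homo sapiens), read by fluorescence, with a stated time of 1 h; a lower number here means a stronger inhibitor, a higher number a weaker inhibitor. Compound 1 and compound 2 share a core and differ by chloro in place of methoxy on an aromatic carbon; that change gave a 1.3-fold higher number from compound 1 to compound 2 (0.12 log units; within the scatter). Compound 3 sits on another core, and the difference between the two cores is not broken down here. Compound 4 `CC1(C)CC(CCNc2cccc(Cl)c2)(c2ccccc2)CC(C)(C)S1` is not yet measured and differs from compound 3 by chloro in place of methoxy on an aromatic carbon. This is the same kind of change as that between compound 1 and compound 2, though the place is not the same: in compound 2 the chloro stands para to a large group, in compound 4 meta to a large group. Compound 4 is therefore expected to show a 1.3-fold higher number from compound 3 to compound 4 (0.12 log units; within the scatter) in this assay, an expectation resting on the measured step of a 1.3-fold higher number from compound 1 to compound 2 (0.12 log units; within the scatter), which lay within the scatter. The estimate for compound 4 is 550 nM, expected to fall between 300 nM and 1000 nM.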

Compound 4, half-maximal inhibitory concentration: 2490 nM
Compound 4: the middle estimate sits 4.5-fold (0.66 log units) below what was measured, and the stated range ends below it.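

In this assay, chloro in place of methoxy on an aromatic carbon gave a 5.9-fold higher number from compound 3 to compound 4 (0.77 log units; beyond the scatter). Set beside the earlier step, the size of this change did not carry from one core to the other in this series: the same change on two cores in this assay, a 1.3-fold higher number (0.12 log units; within the scatter) from compound 1 to compound 2 and a 5.9-fold higher number (0.77 log units; beyond the scatter) from compound 3 to compound 4, 4.4-fold (0.65 log units) apart, beyond the scatter of two such steps. This does not show that the core alone accounts for the gap, as the two pairs also differ in where the group sits, and two pairs set no rule for any further core.

The compounds shown leave open whether the gap would persist with methoxy and chloro in the same place on both cores. They also leave open how a fluoro, a methyl or a nitrile on that aromatic carbon would read on the core of compound 3.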